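Toward a Stronger Inhibitor With One Added Methoxy Group

A few compounds are considered here, and "the series" means these few. Any claim that something is new, unique, unknown or untested is made for them only; others in the source may bear on it.

Compound 1 `COc1cccc(F)c1-c1cccc2nc(Nc3ccccc3)oc12` is the weaker of the two compounds examined in an assay on isolated protein for inhibition of ribosomal protein S6 kinase alpha-2 (Homo sapiens), with a stated time of 150 min; a higher number here means a weaker inhibitor, a lower number a stronger inhibitor. In this assay compound 1 gives 1000 nM. Going by the values given here, the only other measured compound, compound 2 `COc1cc(Nc2nc3cccc(-c4c(F)cccc4OC)c3o2)cc(OC)c1OC`, carries three methoxy groups on the ring attached through nitrogen, and in this assay compound 2 gives 20 nM, a far lower number, well beyond the usual scatter of repeated measurements. Compound 3 `COc1ccc(Nc2nc3cccc(-c4c(F)cccc4OC)c3o2)cc1` has not yet been measured. It differs from compound 1 in one place: methoxy in place of hydrogen on an aromatic carbon, para to a large group. Among the compounds with values here, no pair of measured compounds differs by a single change of this kind, so the size of the step can only be judged from the two numbers already in hand. Because compound 2 gives 20 nM with three methoxy groups in place, a single methoxy group is expected to move the number part of the way down, a step beyond the scatter but smaller than the whole gap. The expected step from compound 1 to compound 3 is a 5.0-fold lower number from compound 1 to compound 3 (0.70 log units; beyond the scatter). Compound 3 is therefore estimated at 200 nM, within a range from 60 nM to 600 nM.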

Compound 3, half-maximal inhibitory concentration: 1400 nM
For compound 3 the middle estimate is 7.0-fold (0.85 log units) below the measured one; measured number outside the range, above it.
By their numbers in this assay, from the lowest: compound 2; then compounds 1 and 3 (each within the scatter of the next).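

In this assay, changing phenyl to 4-methoxyphenyl gives a 1.4-fold higher number from compound 1 to compound 3 (0.15 log units; within the scatter) and so stays within the scatter. Going by these compounds alone, this is the first single change that can be read here, and it shows that one methoxy group in this place, para to a large group, does not by itself bring the number down. Compound 2, with three methoxy groups on the ring attached through nitrogen, gives 20 nM and that low number is not reached with this one group alone, while nothing measured on the compounds explains why the step is so small.

Still open, going by these compounds, is which of the three methoxy groups of compound 2 go with its low number, and whether they work only together or whether one placed elsewhere on the ring would be enough alone. Also open, on these data alone, is how other groups in this same place would fare, such as a hydroxyl group, an amine, a carboxylic acid or a longer chain like ethoxy.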